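The source may hold more compounds than are shown below. What is called first, only, known or untested is meant among the compounds shown, and "the series" means these compounds.

Working notes on the series, read-out an ADME assay on the whole organism (Mus musculus) for pharmacokinetics, at a dose of 10 mg/kg by the oral route; a lower number here means that a smaller share of the oral dose reaches the circulation, a higher number that a larger share of the oral dose reaches the circulation. Compound 1 `CN(Cc1ccccc1)S(=O)(=O)c1ccc(NC(=O)NCc2ccncc2)cc1` gives > 100%, and this is a limit of the assay, not a number. Among the compounds with values here, compound 2 `O=C(NCc1cn[nH]c1)Nc1ccc(S(=O)(=O)c2ccccc2)cc1` gives 45%, which makes it the only true number available in this assay so far.

Compound 3 `O=C(NCc1cn[nH]c1)Nc1ccc(S(=O)(=O)c2ccc(Cl)cc2)cc1` follows from compound 2 by one change: chloro in place of hydrogen on an aromatic carbon, para to a large group, so phenyl to 4-chlorophenyl (chloro in place of hydrogen on an aromatic carbon). Within the data shown here, no measured pair shows this change, so the data give no size or direction for it. The expected step of a number 3 percentage points lower from compound 2 to compound 3 (within the scatter) is none beyond the usual scatter, and the expectation stays anchored on compound 2 at 45%. The wide range reflects that single anchor. For compound 3 the estimated value is 42%, with an expected range from 20% to 68%.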

Compound 3, oral bioavailability: 80%
For compound 3 the middle estimate is 38 percentage points below the measured one; the measured number lies above the stated range.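

In this assay, within the data shown here, chloro in place of hydrogen on an aromatic carbon, para to a large group, gives a number 35 percentage points higher from compound 2 to compound 3 (beyond the scatter), the first step that can be read. The place is therefore not silent in this read-out: a single chlorine atom, with no ring and no hydrogen-bond donors or acceptors added, moves the number beyond the scatter. Compound 1 sits at a limit of the assay and not at a number, and readings in this series can end at that limit: the limit of > 100% in this assay, at which 1 of the 3 values shown sits.

On these data alone, this remains one pair, so it is open whether the step belongs to chloro itself or would also appear with a methoxy group, an amine or a carboxylic acid at the same place. As far as these compounds go, it is equally open whether phenyl to 4-chlorophenyl gives a step of this size on any other core.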